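A hydroxyl piperidine in place of the dimethyl piperidine

This account rests on a few compounds, and the source may have more. Where it says the series, first, only, none or still open, it means among the compounds named here.

Compound 2 `CC1(C)CCN(S(=O)(=O)c2ccc(NC(=O)c3ccc([N+](=O)[O-])o3)cc2)CC1` belongs to a small set of analogues built on a shared core, in which only the substituent on the sulfonyl sulfur varies. In an ADME assay on IMR-90 cells (Homo sapiens) for cytotoxicity, read by CellTiter-Blue, with a stated time of 46 h (on this read-out lower numbers stand for an effect already at smaller amounts and higher numbers for an effect only at larger amounts of compound), compound 2 gives > 25000 nM, which is a limit of the assay and not a number. Compound 1 `CC1CCN(S(=O)(=O)c2ccc(NC(=O)c3ccc([N+](=O)[O-])o3)cc2)CC1` gives in this assay > 25000 nM, likewise a limit. Compound 3 `O=C(Nc1ccc(S(=O)(=O)N2CCC3(CCCCC3)CC2)cc1)c1ccc([N+](=O)[O-])o1` gives in this assay > 25000 nM, again a limit. Compound 2 therefore stands at the limit of > 25000 nM in this assay, at which 3 of the 3 values shown sit, together with every other measured compound.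

Compound 4 `O=C(Nc1ccc(S(=O)(=O)N2CCC(O)CC2)cc1)c1ccc([N+](=O)[O-])o1` differs from compound 2 by 4-hydroxypiperidin-1-yl in place of 4,4-dimethylpiperidin-1-yl on a sulfonyl sulfur. Among the measured compounds shown here, the only measured step, a step that the two limits leave unreadable from compound 1 to compound 2, is of unreadable size and does not involve a hydroxyl, so no measured step bears directly on this change. With all measured values at the same limit, the expected step in this assay is none beyond the scatter, and the estimated step that the limit leaves unreadable from compound 2 to compound 4 reflects that. Compound 4 is therefore expected at 30000 nM, with a range from 12000 nM to 100000 nM, most likely reported again only as a limit.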

Compound 4, half-maximal effective concentration: > 25000 nM
Compound 4: a limit, no number (the forecaster's own chance of this, stated with the estimate: 85%); the middle value is on the limit's open side.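

Compound 4 gives only a limit in this assay, as do compound 1 and compound 2, so neither step to compound 4 can be read: the limit of > 25000 nM in this assay, at which 4 of the 4 values shown sit.

The compounds shown leave open whether any substituent on the sulfonyl sulfur would give a readable number in this assay.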